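From 4-chlorophenyl to 2,3,4-trichlorophenyl on compound 1

The source may report more compounds than this note shows. Statements on the series, on what has been measured and on what is new or still open speak of the compounds shown alone.

In an ADME assay on CHO cells (Cricetulus griseus) for cytotoxicity, read by MTT assay, with a stated time of 68 h (on this read-out lower numbers stand for stronger inhibition and higher numbers for weaker inhibition), compound 1 `O=C(/C=C/c1cccc(OCc2ccccc2)c1)c1ccc(Cl)cc1` gives 43600 nM and compound 2 `Cc1ccc(C(=O)/C=C/c2cccc(OCc3ccccc3)c2)cc1` gives 26400 nM. Among the measured compounds shown here, these are the only two measurements so far, and they lie within the scatter of each other, so compound 1 cannot be separated from its one neighbour. Compound 3 `O=C(/C=C/c1cccc(OCc2ccccc2)c1)c1ccc(Cl)c(Cl)c1Cl` keeps the shared core and changes one group: 2,3,4-trichlorophenyl in place of 4-chlorophenyl on a carbonyl carbon. For the measured compounds named here, the only measured step with any bearing on this is a 1.7-fold lower number from compound 1 to compound 2 (0.22 log units; within the scatter), where methyl replaces chloro on an aromatic carbon. Going by the values given here, that step is small, but it is only a loose guide, since no measured compound carries the 2,3,4-trichlorophenyl group. No step beyond the scatter is therefore expected in this assay. The estimated step is a 1.2-fold lower number from compound 1 to compound 3 (0.10 log units; within the scatter). For compound 3 the expected value is 35000 nM, within an estimated range from 14000 nM to 90000 nM.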

Compound 3, half-maximal inhibitory concentration: 8600 nM
Compound 3: middle estimate off by 4.1-fold (0.61 log units), on the high side; measured number below the stated range.
By their numbers in this assay, from the lowest: compound 3; then compounds 2 and 1 (each within the scatter of the next).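

Both a 5.1-fold lower number from compound 1 to compound 3 (0.70 log units; beyond the scatter) and a 3.1-fold lower number from compound 2 to compound 3 (0.49 log units; beyond the scatter) lie beyond the scatter in this assay and give this series its first clear change. The group on the carbonyl carbon can therefore shift the number, although exchanging 4-chlorophenyl for 4-methylphenyl did not separate compound 1 from compound 2, and compound 3 now has the lowest number of the three. Nothing available here explains why the 2,3,4-trichlorophenyl group has this effect.

From the compounds shown here alone, it remains open whether every chlorine of the 2,3,4-trichlorophenyl group is needed for the lower number, or whether part of the group would give the same result. It is also unknown how this position would respond to a different kind of substituent on the aromatic ring, such as an amine or a carboxylic acid.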